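One Group Swapped on a Shared Core

The source may hold more compounds than are shown below. What is called first, only, known or untested is meant among the compounds shown, and "the series" means these compounds.

Of the compounds shown here, three built on one shared core have numbers so far in a functional assay on C8166 cells (Homo sapiens) for cytotoxicity, read by MTT assay (on this read-out higher numbers stand for lower toxicity in this test and lower numbers for higher toxicity in this test), and each carries a different group on the same carbonyl carbon. Compound 1 (`Cc1cc(S(N)(=O)=O)ccc1NC(=O)COc1ccc(Cl)cc1NC(=O)c1ccccc1`) reads 207000 nM with a plain phenyl there. Compound 2 (`Cc1cc(S(N)(=O)=O)ccc1NC(=O)COc1ccc(Cl)cc1NC(=O)c1cccc(Cl)c1`) reads 59700 nM with a 3-chlorophenyl, and compound 3 (`Cc1cc(S(N)(=O)=O)ccc1NC(=O)COc1ccc(Cl)cc1NC(=O)c1ccccc1[N+](=O)[O-]`) reads 54800 nM with a 2-nitrophenyl. Compound 3 thus stands at the more toxic end of this small set, together with its nearest neighbour: the gap is a 1.1-fold lower number from compound 2 to compound 3 (0.04 log units; within the scatter) and no more.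

Compound 4 (`Cc1cc(S(N)(=O)=O)ccc1NC(=O)COc1ccc(Cl)cc1NC(=O)c1cccc(C(F)(F)F)c1`) has not been measured yet. Its difference from compound 3 is 3-(trifluoromethyl)phenyl in place of 2-nitrophenyl on a carbonyl carbon and puts 3-(trifluoromethyl)phenyl in place of 2-nitrophenyl on a carbonyl carbon. Among the compounds with values here, the nearest precedent for swapping one substituted phenyl for another is a 1.1-fold lower number from compound 2 to compound 3 (0.04 log units; within the scatter) and it stayed within the scatter. Adding a group to the plain phenyl of compound 1 gave the modest steps of a 3.5-fold lower number from compound 1 to compound 2 (0.54 log units; beyond the scatter) and a 3.8-fold lower number from compound 1 to compound 3 (0.58 log units; beyond the scatter) of similar size. No step beyond the scatter is therefore expected in this assay for this swap. The estimate is a 1.0-fold higher number from compound 3 to compound 4 (0.00 log units; within the scatter) and that remains an expectation. Compound 4 is expected near 55000 nM with an estimated range of 25000 nM to 130000 nM as its likely span.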

Compound 4, half-maximal cytotoxic concentration: 124000 nM
For compound 4 the middle estimate is 2.3-fold (0.35 log units) below the measured one, and the stated range covers the measured number.
By their numbers in this assay, from the lowest: compounds 3 and 2 (each within the scatter of the next); then compounds 4 and 1 (each within the scatter of the next).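

Swapping one substituted phenyl for another on this carbonyl carbon can change the number after all: the earlier swap stayed within the scatter (a 1.1-fold lower number from compound 2 to compound 3 (0.04 log units; within the scatter)), but here the result lies beyond it (a 2.3-fold higher number from compound 3 to compound 4 (0.35 log units; beyond the scatter)). The same holds when only the group on the phenyl changes, with trifluoromethyl in place of chloro (a 2.1-fold higher number from compound 2 to compound 4 (0.32 log units; beyond the scatter)), so this assay can tell these two groups apart, even though both compounds carry them on a phenyl named as 3-substituted. Adding a group to the plain phenyl also no longer always gives a step beyond the scatter: compound 2 and compound 3 did, but compound 4 goes against that pattern (a 1.7-fold lower number from compound 1 to compound 4 (0.22 log units; within the scatter)), and nothing available here bears on the reason for these differences.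

The nitro group and the chloro and trifluoromethyl groups also differ in where their names place them, so a 3-nitrophenyl on the same carbonyl carbon would be needed to separate the effect of the group from that of its place. As far as these compounds go, how an amine or a carboxylic acid on this phenyl, or a longer chain in place of the phenyl, would read remains open.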